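Nitro for trichloromethyl on two related cores

The source may hold more compounds than are shown below. What is called first, only, known or untested is meant among the compounds shown, and "the series" means these compounds.

Values in a physicochemical assay for lipophilicity (a higher number here means a more lipophilic compound, a lower number a more polar compound), so far:
compound 1 `CC(=O)Nc1ccc(OC(=S)Nc2ccc(Sc3ccc([N+](=O)[O-])cc3)cc2)cc1`: 5.06
compound 2 `CC(=O)Nc1ccc(OC(=S)Nc2ccc(Sc3ccc(C(Cl)(Cl)Cl)cc3)cc2)cc1`: 6.71
compound 3 `Oc1ccc(OC(=S)Nc2ccc(Nc3ccc(C(Cl)(Cl)Cl)cc3)cc2)cc1`: 6.79

One counted step is known: a number 1.65 log units lower from compound 2 to compound 1 (beyond the scatter), the change being (nitro in place of trichloromethyl on an aromatic carbon). Compound 3 stands on another core; the difference between the cores of compound 2 and compound 3 is not broken down here, and their two numbers lie within the scatter of each other. Compound 4 `O=[N+]([O-])c1ccc(Nc2ccc(NC(=S)Oc3ccc(O)cc3)cc2)cc1` is derived from compound 3 by nitro in place of trichloromethyl on an aromatic carbon, the same change at the same place as between compound 2 and compound 1. The step from compound 3 to compound 4 is expected to be a number 1.65 log units lower from compound 3 to compound 4 (beyond the scatter), because the identical change on the other core produced a number 1.65 log units lower from compound 2 to compound 1 (beyond the scatter). In this assay compound 4 is accordingly expected near 5.14, with a range from 4.65 to 5.65.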

Compound 4, partition coefficient: 4.54
The estimate for compound 4 lay 0.60 log units above the measured number; measured number outside the range, below it.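

In this assay, nitro in place of trichloromethyl on an aromatic carbon gives a number 2.25 log units lower from compound 3 to compound 4 (beyond the scatter), and on the other core the same change gives a number 1.65 log units lower from compound 2 to compound 1 (beyond the scatter). The direction of the step therefore carries across these two cores and both steps are large, but two pairs do not establish one size for the change that could be transferred to a further core. Nothing shown here accounts for the size of either step.

The compounds shown leave open how a nitrile or a carboxylic acid at the same aromatic carbon would stand against nitro and trichloromethyl on either core. They also leave open what each separate difference of the two cores contributes, as compound 2 and compound 3 differ in more than one place.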